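Replacing a chlorophenyl amide with a dihydroindolyl amide

The source may report more compounds than this note shows. Statements on the series, on what has been measured and on what is new or still open speak of the compounds shown alone.

Compound 1, `Cc1cccc(NC(=O)CSc2nnc(-c3ccoc3C)n2Cc2ccco2)c1C`, in a functional assay on CHO cells for antagonist activity at Orexin/Hypocretin receptor type 1 (Homo sapiens), read by FLIPR and calcium flux (on this read-out higher numbers stand for weaker inhibition and lower numbers for stronger inhibition), reaches only a limit of the assay, > 15800 nM.
Compound 2, `Cc1occc1-c1nnc(SCC(=O)Nc2ccc(Cl)cc2)n1Cc1ccco1`, gives 2000 nM in this assay.
Compound 3, `Cc1occc1-c1nnc(SCC(=O)Nc2cccc(Cl)c2)n1Cc1ccco1`, gives 2000 nM in this assay.

All three share one core and differ only in the group on the amide nitrogen. Compound 3 stands level with compound 2 at the digits shown: no change at the digits printed from compound 2 to compound 3 (within the scatter). Against the dimethylphenyl compound the picture is different, with an at least 7.9-fold lower number from compound 1 to compound 3 (0.89 log units; beyond the scatter) and, in parallel, an at least 7.9-fold lower number from compound 1 to compound 2 (0.89 log units; beyond the scatter); both steps start from a limit, (the limit of > 15800 nM in this assay, at which 1 of the 3 values shown sits), so their true size is not known.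

Compound 4, `Cc1occc1-c1nnc(SCC(=O)NN2CCc3ccccc32)n1Cc1ccco1`, carries the change (2,3-dihydro-1H-indol-1-yl in place of 3-chlorophenyl on an amide-type nitrogen). For the measured compounds named here, the measured steps show only that exchanging one substituted phenyl for another can leave the number untouched or move it substantially; no measured step involves a ring system like the one entering, so the direction of this step cannot be read from them. A weakening beyond the scatter is judged somewhat more likely than a gain, but with wide uncertainty. Compound 4 is therefore expected at 4000 nM, somewhere between 1000 nM and 20000 nM. The step this estimate implies is a 2.0-fold higher number from compound 3 to compound 4 (0.30 log units; within the scatter).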

Compound 4, inhibition constant: > 15800 nM
Compound 4: no number, only a limit; the forecaster's own chance of this, stated with the estimate: 25%; at least 3.9-fold (0.59 log units) between middle value and limit.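

On the amide-type nitrogen, the 2,3-dihydro-1H-indol-1-yl group falls well short of both chlorophenyl groups: in this assay there is an at least 7.9-fold higher number from compound 3 to compound 4 (0.89 log units; beyond the scatter), and there is an at least 7.9-fold higher number from compound 2 to compound 4 (0.89 log units; beyond the scatter). The earlier compounds showed that one substituted phenyl can lose out to another here, and compound 4 now shows that a group with a second, non-aromatic ring and a ring nitrogen can also sit far from the chlorophenyl compounds, so among these four only the two chlorophenyl compounds give a number rather than a limit. Compound 4 reaches only a limit, so the two steps give minimum sizes, and compound 1 and compound 4 cannot be compared with each other because both stop at that limit: the limit of > 15800 nM in this assay, at which 2 of the 4 values shown sit.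

From the compounds shown here alone, it remains open whether the loss in compound 4 belongs to the extra ring or to the nitrogen that joins it to the amide-type nitrogen. An unsubstituted phenyl or a methoxyphenyl on the same nitrogen could also test whether the chlorine itself matters.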